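A Hydroxy Group Added to Compound 1

This account rests on a few compounds, and the source may have more. Where it says the series, first, only, none or still open, it means among the compounds named here.

In a functional assay on PANC-1 cells (Homo sapiens) for antiproliferative activity, read by MTT assay, with a stated time of 48 h (on this read-out higher numbers stand for weaker inhibition and lower numbers for stronger inhibition), compound 1 (`COc1ccc(-c2c(Nc3cc(OC)c(OC)c(OC)c3)c3ccccc3oc2=O)cc1`) gives 77600 nM and stands highest of the two measured compounds. Compound 2 (`COc1ccc(-c2c(Nc3ccc(F)cc3)c3ccccc3oc2=O)cc1`) gives 32000 nM and the gap between them lies beyond the usual scatter. Compound 3 (`COc1ccc(-c2c(Nc3cc(OC)c(OC)c(OC)c3)c3ccc(O)cc3oc2=O)cc1`) carries hydroxy in place of hydrogen on an aromatic carbon of the core of compound 1 (hydroxy in place of hydrogen on an aromatic carbon). Within the data shown here, no measured pair shows this change, so only a modest move toward stronger inhibition is expected in this assay. The expected step is a 1.8-fold lower number from compound 1 to compound 3 (0.27 log units; within the scatter) on this estimate. Compound 3 is expected at 42000 nM with an estimated range from 12000 nM to 130000 nM until it is measured.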

Compound 3, half-maximal inhibitory concentration: 63900 nM
Estimate against measurement, compound 3: 1.5-fold (0.18 log units) below; the measured number falls inside the stated range.
By their numbers in this assay, from the lowest: compounds 2, 3 and 1 (each within the scatter of the next, the first and the last beyond it).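

In this assay, hydroxy in place of hydrogen on an aromatic carbon of the shared core gives a 1.2-fold lower number from compound 1 to compound 3 (0.08 log units; within the scatter), so this change leaves compound 1 and compound 3 within the scatter of each other. At this place, meta to a fused ring and para to a fused ring, the added hydroxy therefore brings no clear change in antiproliferative activity. Nothing measured here gives a reason for this result. From the compounds shown here alone, whether an amine or a carboxylic acid on the same carbon would shift the number stays open. So does whether hydroxy would have the same small effect on the core of compound 2.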